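This account rests on a few compounds, and the source may have more. Where it says the series, first, only, none or still open, it means among the compounds named here.

Measured so far in an assay for binding affinity to Corticotropin releasing factor receptor (Rattus norvegicus); a higher number here means a weaker inhibitor, a lower number a stronger inhibitor:
- compound 1, `CCCC(C)n1c(CC)nc2c(-c3ccc(OC)nc3C(F)(F)F)ccnc21`: compound 1 gives 0.6 nM
- compound 2, `CCc1nc2c(-c3ccc(OC)nc3C(F)(F)F)ccnc2n1C(C)CC`: compound 2 gives 0.7 nM

Among the compounds with values here, compound 2 stands at the higher of the two numbers in this assay, but the only step in the set, a 1.2-fold higher number from compound 1 to compound 2 (0.07 log units; within the scatter), is within the scatter, so compound 1 and compound 2 cannot be ordered against each other.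

Compound 3, `CCc1nc2c(-c3ccc(OC)nc3C(F)(F)F)ccnc2n1C(CC)C1CC1`, is compound 2 with cyclopropyl in place of methyl on a saturated chain carbon bound to an aromatic nitrogen and a saturated chain carbon. Within the data shown here, no measured step bears directly on this kind of change. Among the measured compounds shown here, the one step available, a 1.2-fold higher number from compound 1 to compound 2 (0.07 log units; within the scatter), removes a methyl at a different place on the same side chain and was within the scatter; it gives no size for a cyclopropyl entering here. The expectation is therefore set at no step beyond the scatter: no change at the digits printed from compound 2 to compound 3 (within the scatter) is expected. For the measured compounds named here, the range is widened, as no measured step covers this change.

Compound 3 is estimated at 0.7 nM in this assay, with a range from 0.25 nM to 2 nM.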

Compound 3, inhibition constant: 0.7 nM
The estimate for compound 3 equals the measured number at the digits printed, and the stated range covers the measured number.
By their numbers in this assay, from the lowest: compounds 1, 2 and 3 (each within the scatter of the next).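

At the saturated chain carbon bound to an aromatic nitrogen and a saturated chain carbon, cyclopropyl, with three heavy atoms and a ring, takes the place of methyl, with one heavy atom, and this assay gives no change at the digits printed from compound 2 to compound 3 (within the scatter), so this added ring carries no readable cost or gain here. Set against the 1-methylbutyl group, the 1-cyclopropylpropyl group on the aromatic nitrogen gives a 1.2-fold higher number from compound 1 to compound 3 (0.07 log units; within the scatter), and all three side chains now lie within the scatter of one another in this assay. No evidence on the reason for this flat reading is at hand.

All three side chains shown consist of carbon and hydrogen only, so a side chain bearing a hydroxyl, an amine or a phenyl ring remains open at this carbon. On these data alone, how far chain size can grow before the number moves beyond the scatter also remains open.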